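Chloro for Fluoro on Two Related Sulfonamide Cores

The source may report more compounds than this note shows. Statements on the series, on what has been measured and on what is new or still open speak of the compounds shown alone.

In a functional assay on A-431 cells (Homo sapiens) for antiproliferative activity, read by MTT assay, with a stated time of 72 h (on this read-out higher numbers stand for weaker inhibition and lower numbers for stronger inhibition), compound 1 `COc1cc2ncnc(Nc3ccc(F)cc3)c2cc1OCCCCC(=O)Nc1ccc(S(N)(=O)=O)cc1` gives 18600 nM. Compound 2 `COc1cc2ncnc(Nc3ccc(Cl)cc3)c2cc1OCCCCC(=O)Nc1ccc(S(N)(=O)=O)cc1` differs from it by chloro in place of fluoro on an aromatic carbon, and in this assay compound 2 gives 7120 nM. That single change produced a 2.6-fold lower number from compound 1 to compound 2 (0.42 log units; beyond the scatter).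

Compound 3 `NS(=O)(=O)c1ccc(NC(=S)Nc2ccc3ncnc(Nc4cccc(F)c4)c3c2)cc1` is built on a different core; the difference between the cores of compound 1 and compound 3 is not broken down here. In this assay compound 3 gives 30100 nM, a number within the scatter of compound 1 and beyond the scatter of compound 2.

Compound 4 `NS(=O)(=O)c1ccc(NC(=S)Nc2ccc3ncnc(Nc4cccc(Cl)c4)c3c2)cc1` carries chloro in place of fluoro on an aromatic carbon. Among the measured compounds shown here, this is the same kind of change as the one from compound 1 to compound 2, but the place is not the same: there the chloro stands para to a large group, here it stands meta to a large group. The step from compound 3 to compound 4 is expected to be a 2.0-fold lower number from compound 3 to compound 4 (0.30 log units; within the scatter), a little smaller than the earlier one because the earlier change gave a 2.6-fold lower number from compound 1 to compound 2 (0.42 log units; beyond the scatter) at a different place. Compound 4 is therefore estimated at 15000 nM, expected to fall between 6000 nM and 40000 nM.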

Compound 4, half-maximal inhibitory concentration: 15000 nM
Compound 4: middle estimate and measured number agree at the digits printed; low and high end bracket the measured number.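

In this assay, chloro in place of fluoro on an aromatic carbon gives a 2.0-fold lower number from compound 3 to compound 4 (0.30 log units; within the scatter), and set beside the earlier step, the two cores do not come apart: the same change on two cores in this assay, a 2.6-fold lower number (0.42 log units; beyond the scatter) from compound 1 to compound 2 and a 2.0-fold lower number (0.30 log units; within the scatter) from compound 3 to compound 4, 1.3-fold (0.11 log units) apart, within the scatter of two such steps. Both steps run the same way and are of similar size, which fits the change carrying over from the core of compound 1 to the core of compound 3, but only the earlier step lies beyond the scatter, so the new step does not establish an effect on the second core by itself. The chloro also stands at a different place on the two cores, so the effect of the core cannot be separated from that of the place, and two pairs set no rule for the wider series.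

The compounds shown leave open whether bromo, trifluoromethyl or an amine at the same aromatic carbon would follow the halogen step. They also leave open whether the step would hold with the fluoro and chloro swapped at the same place on each core.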